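Bromo to hydroxy on the shared core: outlook for compound 3

The source may report more compounds than this note shows. Statements on the series, on what has been measured and on what is new or still open speak of the compounds shown alone.

Of the compounds shown here, two of the shared core have been measured. Compound 1 `C=C1[C@@H](OC(C)=O)C[C@@H]2[C@](C)(CO[Si](C)(C)C(C)(C)C)[C@H](OC(C)=O)CC[C@@]2(C)[C@@H]1C[C@@H](Nc1ccccc1F)C1=CCOC1=O` gives 3710 nM in a functional assay on HT-29 cells (Homo sapiens) for cytotoxicity, read by sulforhodamine B assay; a lower number here means a stronger inhibitor, a higher number a weaker inhibitor. Compound 2 `C=C1[C@@H](OC(C)=O)C[C@@H]2[C@](C)(COC=O)[C@H](OC(C)=O)CC[C@@]2(C)[C@@H]1C[C@@H](Nc1ccc(Br)cc1)C1=CCOC1=O` gives 13200 nM in this assay, the highest of the two numbers; compound 1 lies a step below it, beyond the scatter. Compound 3 `C=C1[C@@H](OC(C)=O)C[C@@H]2[C@](C)(COC=O)[C@H](OC(C)=O)CC[C@@]2(C)[C@@H]1C[C@@H](Nc1ccc(O)cc1)C1=CCOC1=O` carries hydroxy in place of bromo on an aromatic carbon. Among the compounds with values here, no measured pair shows this change, so its effect is unknown here. The expected step of a 1.1-fold higher number from compound 2 to compound 3 (0.06 log units; within the scatter) is small, likely within the scatter, with no clear direction. Compound 3 is estimated at 15000 nM, with a range from 5000 nM to 45000 nM in this assay.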

Compound 3, half-maximal inhibitory concentration: 13400 nM
Beside the measured number, compound 3's estimate is 1.1-fold (0.05 log units) above it; measured number inside the range.
By their numbers in this assay, from the lowest: compound 1; then compounds 2 and 3 (each within the scatter of the next).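

At this place on the aromatic ring, para to a large group, hydroxy in place of bromo gives a 1.0-fold higher number from compound 2 to compound 3 (0.01 log units; within the scatter) in this assay so the two numbers lie within the scatter of each other. The hydrogen-bond donor and acceptor that hydroxy brings thus separate it from bromo by no readable margin in this read-out. Nothing on hand speaks to why this is so.

Open, on these data alone, is whether an amine or a carboxylic acid in the same place would also stay within the scatter of these two compounds. Also open, as far as these compounds go, is whether a longer chain there would do the same.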